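Replacing 2-ethylphenyl on the sulfonamide nitrogen of compound 1

The compounds below may be only part of what the source reports. "The series", "measured", "known", "first", "only" and "open" are said of these compounds alone.

In a functional assay on M21 cells (Homo sapiens) for antiproliferative activity, read by sulforhodamine B assay, with a stated time of 48 h (a lower number here means a stronger inhibitor, a higher number a weaker inhibitor), compound 1 `CCc1ccccc1NS(=O)(=O)c1ccc(N2CCNC2=O)cc1` gives 180 nM, compound 2 `Cc1ccc(NS(=O)(=O)c2ccc(N3CCNC3=O)cc2)cc1C` gives 94 nM and compound 3 `O=C1NCCN1c1ccc(S(=O)(=O)Nc2ccc(I)cc2)cc1` gives 260 nM. Compound 1 thus stands within the scatter of both others, and only the remaining pair separates: a 2.8-fold higher number from compound 2 to compound 3 (0.44 log units; beyond the scatter). Compound 4 `O=C1NCCN1c1ccc(S(=O)(=O)Nc2ccc(F)c(F)c2)cc1` differs from compound 1 as follows: 3,4-difluorophenyl in place of 2-ethylphenyl on a sulfonamide nitrogen. In words, 3,4-difluorophenyl stands in place of 2-ethylphenyl on a sulfonamide nitrogen. Two measured steps replace the same group: a 1.9-fold lower number from compound 1 to compound 2 (0.28 log units; within the scatter) and a 1.4-fold higher number from compound 1 to compound 3 (0.16 log units; within the scatter). Neither leaves the scatter, so no step beyond the scatter is expected in this assay. The expected step is a 1.1-fold lower number from compound 1 to compound 4 (0.02 log units; within the scatter). For compound 4 the estimated value is 170 nM, with an expected range of 70 nM to 400 nM.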

Compound 4, half-maximal inhibitory concentration: 220 nM
The estimate for compound 4 lay 1.3-fold (0.11 log units) below the measured number; measured number inside the range.
By their numbers in this assay, from the lowest: compounds 2, 1, 4 and 3 (each within the scatter of the next, the first and the last beyond it).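

In this assay, 3,4-difluorophenyl on the sulfonamide nitrogen stays within the scatter of both 2-ethylphenyl (a 1.2-fold higher number from compound 1 to compound 4 (0.09 log units; within the scatter)) and 4-iodophenyl (a 1.2-fold lower number from compound 3 to compound 4 (0.07 log units; within the scatter)). The new information is the separation between two 3,4-disubstituted phenyl groups, 3,4-difluorophenyl and 3,4-dimethylphenyl (a 2.3-fold higher number from compound 2 to compound 4 (0.37 log units; beyond the scatter)), although compound 1 remains within the scatter of compound 2. No evidence here bears on what lies behind this gap.

Still open, going by these compounds, is whether an amine or a carboxylic acid on the phenyl ring would stay within this narrow band. Also open, on these data alone, is whether a longer chain in place of the phenyl ring would do so.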